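A few compounds are considered here, and "the series" means these few. Any claim that something is new, unique, unknown or untested is made for them only; others in the source may bear on it.

Measured compounds and their values:
Compound 1, `CCCc1ccccc1-n1nc(C)c2c1NC(=O)[C@H](C)S[C@@H]2c1ccc(Oc2ccccc2)cc1`, gives 240% in an assay on isolated protein for agonist activity at Bile acid receptor (Homo sapiens), read by AlphaScreen, with a stated time of 30 min; a lower number here means a smaller maximal response, a higher number a larger maximal response.
Compound 2, `Cc1ccccc1-n1nc(C)c2c1NC(=O)[C@H](C)S[C@@H]2c1ccc(-c2cc3ccccc3o2)cc1`, gives 17% in this assay.
Compound 3, `Cc1nn(-c2ccccc2Cl)c2c1C(c1ccc(Oc3ccccc3)cc1)SC(C)C(=O)N2`, gives 57% in this assay.

Among these three numbers compound 3 stands second highest. Its nearest neighbour is compound 2, whose number lies lower by a margin beyond the usual scatter; furthest away is compound 1, whose number lies higher by a much wider margin, again beyond the scatter.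

Compound 4, `Cc1nn(-c2ccccc2F)c2c1C(c1ccc(Oc3ccccc3)cc1)SC(C)C(=O)N2`, has not yet been measured in this assay. It differs from compound 3 in a single place: fluoro in place of chloro on an aromatic carbon. For the measured compounds named here, no pair of measured compounds differs in just this way, so the data give no measured step of this kind. The rest of the molecule is unchanged, and the step expected in this assay is one that stays within the usual scatter, in no firm direction, with a slight allowance toward a smaller maximal response.

For compound 4 the expected value in this assay is estimated at 50%, within a range from 20% to 110%. This estimate means an expected step of a number 7 percentage points lower from compound 3 to compound 4 (within the scatter).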

Compound 4, largest response reached (reported as efficacy), in percent of the reference or control that the assay uses: 72%
Compound 4: the middle estimate sits 22 percentage points below what was measured; low and high end bracket the measured number.
By their numbers in this assay, from the lowest: compound 2; then compound 3; then compound 4; then compound 1.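

In this assay, replacing chloro with fluoro on an aromatic carbon ortho to a large group, with the rest of the molecule unchanged, gives a number 15 percentage points higher from compound 3 to compound 4 (beyond the scatter). For the compounds shown here, this is the first single-place comparison, and it shows that the maximal response at this position is sensitive to the identity of one halogen, even though the exchange swaps one heavy atom for another and adds or removes no ring, hydrogen-bond donor, hydrogen-bond acceptor or net charge. Nothing available here explains why the response shifts with this exchange.

The compounds shown leave open how a methoxy group, a nitrile or an amine at this same place would compare with chloro and fluoro, as this pair covers only two halogens. They also leave open whether the exchange of chloro for fluoro would shift the response in the same direction and by a similar size if the rest of the molecule were different, as this single pair offers only one setting for it.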